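A few compounds are considered here, and "the series" means these few. Any claim that something is new, unique, unknown or untested is made for them only; others in the source may bear on it.

Measured so far, in a functional assay on DLD-1 cells (Homo sapiens) for antiproliferative activity, read by CellTiter-Glo, with a stated time of 72 h; on this read-out lower numbers stand for stronger inhibition and higher numbers for weaker inhibition:
compound 1 `Cc1cc(C)c(S(=O)(=O)N2CCC(N3CCC(O)CC3)CC2)c(C)c1` — 106 nM
compound 2 `Cc1cc(C)c(S(=O)(=O)c2ccc(N3CCC(C)CC3)cc2)c(C)c1` — > 5000 nM, a limit of the assay, not a number
compound 3 `CC1CCN(C2CCN(S(=O)(=O)c3nccn3C)CC2)CC1` — > 5000 nM, also a limit of the assay

Going by the values given here, compound 1 is the only compound of the three with a real number in this assay. Among the compounds with values here, the other two values are the limit of > 5000 nM in this assay, at which 2 of the 3 values shown sit, so no step between measured compounds can be read off, and neither compound 2 nor compound 3 differs from compound 1 in one place only.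

The next compound, compound 4 `Cc1cc(C)c(S(=O)(=O)N2CCC(N3CCC(C(C)C)CC3)CC2)c(C)c1`, keeps the core of compound 1 and changes only the substituent on the outer saturated ring: isopropyl in place of hydroxy on a saturated ring carbon. Within the data shown here, no measured step of this kind exists in the set, so the size and direction of the change rest on no data here.

The step of a 2.4-fold higher number from compound 1 to compound 4 (0.37 log units; beyond the scatter) is expected to be small, if anything toward weaker inhibition. For compound 4 the estimate in this assay is 250 nM, with a range from 50 nM to 1500 nM.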

Compound 4, half-maximal inhibitory concentration: 0.3 nM
Beside the measured number, compound 4's estimate is 830-fold (2.92 log units) above it; measured number outside the range, below it.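

In this assay, this position on the outer ring proves highly sensitive to its substituent: isopropyl in place of hydroxy gives a 350-fold lower number from compound 1 to compound 4 (2.55 log units; beyond the scatter). On the core of compound 1, hydroxy is therefore not needed for activity, and the change leaves this substituent with no hydrogen-bond donor or acceptor while the number falls sharply. Nothing measured here accounts for the size of this step.

On these data alone, whether the step follows the loss of hydroxy or the arrival of the branched carbon group stays open; an ethyl, a tert-butyl, a methoxy or an amine at the same ring carbon would help separate the two. Compound 2 and compound 3 give no readable steps, since each differs from compound 1 and compound 4 in more than one place and carries only a limit: the limit of > 5000 nM in this assay, at which 2 of the 4 values shown sit.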